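From phenyl to 4-nitrophenyl: what to expect

The source may hold more compounds than are shown below. What is called first, only, known or untested is meant among the compounds shown, and "the series" means these compounds.

Measured in an ADME assay on PC-12 cells (Rattus norvegicus) for cytotoxicity, read by MTT assay, with a stated time of 24 h; a higher number here means that more compound is tolerated, a lower number that less compound is tolerated:
- compound 1 `Cc1ccc(C#N)c(N2CCN(CC#CCOC(=O)c3sc4ncnc(N5CCCCC5)c4c3C)CC2)c1`: 114 ug/mL
- compound 2 `Cc1c(C(=O)OCC#CCN2CCN(c3cc(C4CC4)ccc3C#N)CC2)sc2ncnc(N3CCCCC3)c12`: 148 ug/mL
- compound 3 `Cc1c(-c2nnc(-c3ccccc3)o2)sc2ncnc(N3CCCCC3)c12`: 146 ug/mL

Compound 3 cannot be told apart from compound 1 or compound 2, since its value lies within the usual scatter of both. Compound 4 `Cc1c(-c2nnc(-c3ccc([N+](=O)[O-])cc3)o2)sc2ncnc(N3CCCCC3)c12` differs from compound 3 in one place: nitro in place of hydrogen on an aromatic carbon. This puts nitro in place of hydrogen on an aromatic carbon, turning phenyl into 4-nitrophenyl.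

For the measured compounds named here, only one measured step exists, a 1.3-fold higher number from compound 1 to compound 2 (0.11 log units; within the scatter). It is a different change, made on compounds with a different side chain, so it offers only weak guidance. Going by the values given here, no measured pair shows what adding nitro does here. The three values do sit close together, however, despite their differing structures. The estimate therefore starts from compound 3 at 146 ug/mL, and no shift beyond the scatter is expected, in either direction. The expected step is a 1.1-fold lower number from compound 3 to compound 4 (0.03 log units; within the scatter). For compound 4 the estimated value is 135 ug/mL, with an expected range from 70 ug/mL to 240 ug/mL.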

Compound 4, half-maximal cytotoxic concentration: 145 ug/mL
For compound 4 the middle estimate is 1.1-fold (0.03 log units) below the measured one, within the range that was stated.
By their numbers in this assay, from the lowest: compounds 1, 4, 3 and 2 (each within the scatter of the next).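

In this assay, for the compounds shown here, the change on the phenyl ring can now be read directly for the first time, as a measured pair gives a 1.0-fold lower number from compound 3 to compound 4 (0.00 log units; within the scatter). At this place, para to a large group on the six-membered aromatic ring, nitro in place of hydrogen adds three heavy atoms, yet compound 4 cannot be told apart from compound 3 in this cell test. No supporting measurement is available to explain this, so it stands as an observation only.

A single nitro compound cannot show whether every group is tolerated at this place, and an amine, a carboxylic acid or a longer chain such as butyl could give a different result. The compounds shown also leave open whether nitro elsewhere on the phenyl ring would leave the number just as unchanged.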